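Chloro for Fluoro on a Thiophene-Bearing Core

A few compounds are considered here, and "the series" means these few. Any claim that something is new, unique, unknown or untested is made for them only; others in the source may bear on it.

The series shares one core and varies two positions. Compound 1 `COc1cc(-c2nnc3n2NC(c2ccco2)C(C(=O)c2ccc(Cl)cc2)S3)cc(OC)c1OC` carries a furan-2-yl group and a 4-chlorophenyl carbonyl; in a functional assay on HepG2 cells (Homo sapiens) for cytotoxicity, read by MTT assay, with a stated time of 48 h (on this read-out higher numbers stand for weaker inhibition and lower numbers for stronger inhibition), compound 1 gives 78600 nM. Compound 2 `COc1cc(-c2nnc3n2NC(c2ccco2)C(C(=O)c2ccc(F)cc2)S3)cc(OC)c1OC` differs only by fluoro in place of chloro on an aromatic carbon. In this assay compound 2 reaches only a limit of the assay, > 100000 nM, and the limit of > 100000 nM in this assay, at which 1 of the 3 values shown sits, is where that sits. Compound 3 `COc1cc(-c2nnc3n2NC(c2cccs2)C(C(=O)c2ccc(F)cc2)S3)cc(OC)c1OC` replaces furan-2-yl with thiophen-2-yl on a saturated ring carbon; in this assay compound 3 gives 54200 nM. Compound 3 and compound 1 lie within the scatter of each other; the third value is a limit.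

Compound 4 `COc1cc(-c2nnc3n2NC(c2cccs2)C(C(=O)c2ccc(Cl)cc2)S3)cc(OC)c1OC` is not yet measured and differs from compound 3 by chloro in place of fluoro on an aromatic carbon. Going by the values given here, the step that bears on it is the reverse of the one from compound 1 to compound 2, which gave an at least 1.2-fold higher number from compound 1 to compound 2 (0.10 log units; that floor lies within the scatter). The step of an at least 1.8-fold lower number from compound 2 to compound 3 (0.26 log units; that floor lies within the scatter) shows the other position and does not inform this change. A step of at most the same modest size, toward a lower number, is expected, so the estimated step of a 1.4-fold lower number from compound 3 to compound 4 (0.13 log units; within the scatter) stays within the scatter. Compound 4 is therefore expected to give about 40000 nM, between 15000 nM and 100000 nM.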

Compound 4, half-maximal inhibitory concentration: 13200 nM
Compound 4: the middle estimate sits 3.0-fold (0.48 log units) above what was measured, and the stated range ends above it.
By their numbers in this assay, from the lowest: compound 4; then compounds 3 and 1 (each within the scatter of the next). At a limit, above all of these: compound 2.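

On the core bearing thiophen-2-yl, chloro in place of fluoro on an aromatic carbon gives a 4.1-fold lower number from compound 3 to compound 4 (0.61 log units; beyond the scatter) in this assay, the only reading of this change with a number at both ends, and it shows that the change at this position can carry a step beyond the scatter; set beside the earlier step, it reads: the same change on two cores in this assay, an at least 1.2-fold higher number (0.10 log units; that floor lies within the scatter) from compound 1 to compound 2 and a 4.1-fold higher number (0.61 log units; beyond the scatter) from compound 4 to compound 3; the limit leaves it open whether they differ

Thiophen-2-yl in place of furan-2-yl, now read with the 4-chlorophenyl carbonyl in place, gives a 6.0-fold lower number from compound 1 to compound 4 (0.77 log units; beyond the scatter), so this change also has a measured size and not just a floor; beside the earlier step it reads: the same change on two cores in this assay, an at least 1.8-fold lower number (0.26 log units; that floor lies within the scatter) from compound 2 to compound 3 and a 6.0-fold lower number (0.77 log units; beyond the scatter) from compound 1 to compound 4; the limit leaves it open whether they differ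

Of the numbers shown, only compound 4 stands apart, while compound 3 and compound 1 stay within the scatter of each other.

The compounds shown leave open how a bromo or a methoxy group would read at the same place on the six-membered aromatic ring, where only fluoro and chloro appear here. Also open, on these data alone, is whether a phenyl group in place of thiophen-2-yl on the saturated ring carbon would keep the number as low.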